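The source may report more compounds than this note shows. Statements on the series, on what has been measured and on what is new or still open speak of the compounds shown alone.

Compound 3 `COc1cc(Cl)cc(-c2nn(-c3cccc(NC(=O)Nc4ccc(Cl)c(C(F)(F)F)c4)c3)cc2-c2ccncc2)c1` is one of three analogues sharing a core, measured in a functional assay on OVCAR-3 cells (Homo sapiens) for inhibition, read by sulforhodamine B assay, with a stated time of 48 h, tested at 10 uM; a higher number here means a weaker effect of the compound at the concentration tested, a lower number a stronger effect. Compound 1 `O=C(Nc1cccc(-n2cc(-c3ccncc3)c(-c3cc(O)cc(Cl)c3)n2)c1)Nc1ccc(Cl)c(C(F)(F)F)c1` gives 1.88%, compound 2 `O=C(Nc1cccc(-n2cc(-c3ccncc3)c(-c3cc(O)cc(Cl)c3)n2)c1)Nc1ccc(Cl)c(Cl)c1` gives -47.4%, and compound 3 gives -22.6%, the second highest of the three numbers; the step of a number 24.5 percentage points lower from compound 1 to compound 3 (beyond the scatter) separates it from compound 1, and compound 2 sits further off on the lower side. Compound 4 `COc1cc(Cl)cc(-c2nn(-c3cccc(NC(=O)Nc4cccc(C(F)(F)F)c4)c3)cc2-c2ccncc2)c1` differs from compound 3 by hydrogen in place of chloro on an aromatic carbon. Among the measured compounds shown here, no measured step makes this same change; the nearest is a number 49.3 percentage points lower from compound 1 to compound 2 (beyond the scatter), on the same ring, which shows that a change there can move the read-out by a large amount, though in a direction that cannot be carried over directly. The step of a number 7.6 percentage points higher from compound 3 to compound 4 (within the scatter) is therefore expected to be modest and uncertain in direction. Compound 4 is estimated at -15%, within -50% to 15%.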

Compound 4, a percentage reported as activity, at one concentration (the size of the read-out at that concentration, not a potency): -0.41%
For compound 4 the middle estimate is 14.6 percentage points below the measured one, and the stated range covers the measured number.
By their numbers in this assay, from the lowest: compound 2; then compound 3; then compounds 4 and 1 (each within the scatter of the next).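

With hydrogen in place of chloro on the 4-chloro-3-(trifluoromethyl)phenyl ring, this assay gives a step of a number 22.2 percentage points higher from compound 3 to compound 4 (beyond the scatter), so the chloro para to a large group matters to the read-out in this pair. Among the compounds shown here, the earlier step on this ring replaced the trifluoromethyl and kept this chloro, so this is the first direct reading of the chloro position. Nothing given here bears on why the number moves.

On these data alone, whether the same change behaves alike with the hydroxyl of compound 1 remains open. So does what a fluoro, a methyl or an amine would give on this carbon.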